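The source may hold more compounds than are shown below. What is called first, only, known or untested is meant among the compounds shown, and "the series" means these compounds.

Compound 1 `COC(=O)[C@@]1(C)C[C@@H](c2coc3ccc(Br)cc3c2=O)N(c2ccccc2)O1` is the starting point of this account. In a functional assay on PC-3 cells (Homo sapiens) for inhibition, read by sulforhodamine B assay, with a stated time of 48 h (on this read-out higher numbers stand for weaker inhibition and lower numbers for stronger inhibition), compound 1 reaches only a limit, > 60000 nM, so no number is known for it. Its standing among the two values shown is therefore fixed by that limit alone: the limit of > 60000 nM in this assay, at which 1 of the 2 values shown sits. Within the data shown here, the other measured compound, compound 2 `N#C[C@H]1C[C@@H](c2coc3ccc(Cl)cc3c2=O)N(c2ccccc2)O1`, differs from compound 1 in more than one place, so no single step connects the two; in this assay compound 2 gives 41000 nM, a weak inhibition that nonetheless yields a number rather than a limit. Among the measured compounds shown here, no step between measured compounds that differ in one place is available, so the change to compound 3 must rest on the structures themselves. Compound 3 `COC(=O)[C@@]1(C)C[C@@H](c2coc3ccc(C)cc3c2=O)N(c2ccccc2)O1` arises from compound 1 by methyl in place of bromo on an aromatic carbon. Because compound 1 shows > 60000 nM, the step from compound 1 to compound 3 is expected to be small, a step that the limit leaves unreadable from compound 1 to compound 3, with no direction that would stand out beyond the scatter. Compound 3 is therefore estimated at 70000 nM in this assay, within a range from 30000 nM to 160000 nM, and it is quite possible that only a limit is reported for it again.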

Compound 3, half-maximal inhibitory concentration: > 60000 nM
Compound 3 ended at the assay's limit; the forecaster's own chance of this, stated with the estimate: 60%; the middle value lies beyond the limit too.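

Compound 3 gives > 60000 nM in this assay as a limit and not a number. Compound 1 also stands at a limit, so no step can be read between compound 1 and compound 3: the limit of > 60000 nM in this assay, at which 2 of the 3 values shown sit. The compounds shown leave open whether methyl and bromo on this aromatic carbon differ in this assay at all.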